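Stereocentre inversion on the hydroxycyclohexyl of compound 2

The source may hold more compounds than are shown below. What is called first, only, known or untested is meant among the compounds shown, and "the series" means these compounds.

Compound 1 `CCOC(=O)NCCOc1ccc(CC2CCCCC2=O)cc1` gives 0.008 mg/kg in a functional assay on the whole organism for inhibition, with Dysdercus cingulatus as the target; a higher number here means that more compound is needed for the effect, a lower number that less compound is needed. Compound 2 `CCOC(=O)NCCOc1ccc(C[C@@H]2CCCC[C@@H]2O)cc1` carries a 2-hydroxycyclohexyl in place of the 2-oxocyclohexyl, and in this assay compound 2 gives 0.001 mg/kg, the lowest of the two numbers; the step of an 8.0-fold lower number from compound 1 to compound 2 (0.90 log units; beyond the scatter) was modest. Compound 3 `CCOC(=O)NCCOc1ccc(C[C@H]2CCCC[C@@H]2O)cc1` differs from compound 2 in that (the two compounds have the same atoms and bonds and differ only in configuration as drawn: 1 of 2 stereo elements differ; a stereocentre at a saturated ring carbon is drawn S in compound 2 and R in compound 3). Within the data shown here, no measured step concerns configuration, so nothing seen so far bears directly on it. He therefore expects a step of roughly a 3.0-fold higher number from compound 2 to compound 3 (0.48 log units; beyond the scatter), and estimates that compound 3 will give 0.003 mg/kg, within 0.0007 mg/kg to 0.015 mg/kg.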

Compound 3, dose for half-maximal effect: 0.04 mg/kg
Compound 3: middle estimate off by 13-fold (1.12 log units), on the low side; the measured number lies above the stated range.
By their numbers in this assay, from the lowest: compound 2; then compound 1; then compound 3.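

In this assay, configuration at this saturated ring carbon matters, with a 40-fold higher number from compound 2 to compound 3 (1.60 log units; beyond the scatter). Putting 2-hydroxycyclohexyl in place of 2-oxocyclohexyl therefore does not lower the number by itself, since the opposite direction appears with a 5.0-fold higher number from compound 1 to compound 3 (0.70 log units; beyond the scatter). The large step can be tied to stereochemistry alone: the fact that compounds 2 and 3 differ only in the configuration as drawn.

From the compounds shown here alone, the effect of inverting the other stereocentre, which is the same as drawn in compound 2 and compound 3, remains open. So does whether an amine or a methoxy group in place of the hydroxyl would show the same dependence on configuration.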